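Changing the ester chain of compound 3

A few compounds are considered here, and "the series" means these few. Any claim that something is new, unique, unknown or untested is made for them only; others in the source may bear on it.

In a functional assay on M4E cells (Homo sapiens) for cytotoxicity, read by resazurin assay, with a stated time of 72 h (a higher number here means a weaker inhibitor, a lower number a stronger inhibitor), compound 3 `COc1cc(/C=C/C(=O)OCCCO[N+](=O)[O-])ccc1O` gives 18400 nM and compound 2 `COc1cc(/C=C/C(=O)OCCCCCO[N+](=O)[O-])ccc1O` gives 21800 nM, two numbers that lie within the scatter of each other. Compound 1 `COc1cc(/C=C/C(=O)OCCCO[N+](=O)[O-])ccc1OCCCO[N+](=O)[O-]` reaches only a limit of the assay at > 50000 nM.

Compound 4 `COc1cc(/C=C/C(=O)OC/C=C/CO[N+](=O)[O-])ccc1O` has not been measured yet. It differs from compound 3 in its ester chain: a group of 7 heavy atoms (3 carbon, 1 nitrogen, 3 oxygen; no ring) in place of a group of 6 heavy atoms (2 carbon, 1 nitrogen, 3 oxygen; no ring), on a saturated chain carbon bound to an oxygen next to a carbonyl group. The closest guide is a 1.2-fold lower number from compound 2 to compound 3 (0.07 log units; within the scatter), a change in the same chain that stays within the scatter. The other measured step is an at least 2.7-fold lower number from compound 1 to compound 3 (0.43 log units; beyond the scatter), which goes beyond the scatter but alters a different part of the molecule, so it says little here. No step beyond the scatter is therefore expected in this assay. The expected change is a 1.0-fold higher number from compound 3 to compound 4 (0.01 log units; within the scatter). Compound 4 is estimated at 19000 nM, with an expected range from 9500 nM to 38000 nM.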

Compound 4, half-maximal inhibitory concentration: 9380 nM
Beside the measured number, compound 4's estimate is 2.0-fold (0.31 log units) above it; measured number below the stated range.
By their numbers in this assay, from the lowest: compounds 4, 3 and 2 (each within the scatter of the next, the first and the last beyond it). At a limit, above all of these: compound 1.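

In this assay, a chain with 2 double bonds outside aromatic rings replaces 2-(nitrooxy)ethyl, which has 1, on a saturated chain carbon bound to an oxygen next to a carbonyl group, and the result is a 2.0-fold lower number from compound 3 to compound 4 (0.29 log units; within the scatter). For the compounds shown here, the earlier step in this chain compared only saturated chains, so this is the first sign that a chain containing a carbon-carbon double bond can stand here without a step beyond the scatter. No measurement shown explains the value of compound 4.

The compounds shown leave open how an amine, a carboxylic acid or a ring in the ester chain would behave. They also leave open whether a small group such as methyl on the aromatic oxygen would behave differently from the 3-(nitrooxy)propyl group.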